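The source may report more compounds than this note shows. Statements on the series, on what has been measured and on what is new or still open speak of the compounds shown alone.

In a functional assay on the whole organism (strain Wistar albino) for inhibition, with Rattus norvegicus as the target, read by paw edema, with a stated time of 1 h, at a dose of 25 mg/kg by the oral route (on this read-out lower numbers stand for less inhibition and higher numbers for more inhibition at the one dose given (going by the name of the read-out)), compound 1 `CSc1nn(-c2ccccc2)c2nc(Nc3ccccc3)n(-c3ccccc3)c(=O)c12` gives 46.1%. Compound 2 `CSc1nn(-c2ccc([N+](=O)[O-])cc2)c2nc(Nc3ccccc3)n(-c3ccccc3)c(=O)c12` differs from it by nitro in place of hydrogen on an aromatic carbon, and the step is a number 4 percentage points lower from compound 1 to compound 2 (within the scatter), so compound 2 gives 42.1%. Compound 3 `Cc1ccc(Nc2nn(-c3ccccc3)c3nc(Nc4ccccc4)n(-c4ccccc4)c(=O)c23)cc1` gives 55.7% in this assay. Compound 4 `Cc1ccc(Nc2nn(-c3ccc([N+](=O)[O-])cc3)c3nc(Nc4ccccc4)n(-c4ccccc4)c(=O)c23)cc1` has not yet been measured; it differs from compound 3 by nitro in place of hydrogen on an aromatic carbon, the same change seen between compound 1 and compound 2, made on the same place. The two cores differ by (4-methylphenyl)amino in place of methylsulfanyl on an aromatic carbon, a step of a number 9.6 percentage points higher from compound 1 to compound 3 (within the scatter). The earlier nitro step was small, so the step from compound 3 to compound 4 is expected to be a number 3.7 percentage points lower from compound 3 to compound 4 (within the scatter), because the earlier step was a number 4 percentage points lower from compound 1 to compound 2 (within the scatter). Compound 4 is therefore estimated at 52%, between 42% and 62%.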

Compound 4, a percentage reported as inhibition, in the whole organism at one dose (the size of the read-out at that dose, not a potency): 46.6%
Estimate against measurement, compound 4: 5.4 percentage points above; measured number inside the range.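

On the core with the (4-methylphenyl)amino group, nitro in place of hydrogen is a number 9.1 percentage points lower from compound 3 to compound 4 (within the scatter), which agrees with the step on the other core: the same change on two cores in this assay, a number 4 percentage points lower (within the scatter) from compound 1 to compound 2 and a number 9.1 percentage points lower (within the scatter) from compound 3 to compound 4, 5.1 percentage points apart, within the scatter of two such steps. With nitro present, (4-methylphenyl)amino in place of methylsulfanyl is a number 4.5 percentage points higher from compound 2 to compound 4 (within the scatter), which also agrees with its earlier counterpart: the same change on two cores in this assay, a number 9.6 percentage points higher (within the scatter) from compound 1 to compound 3 and a number 4.5 percentage points higher (within the scatter) from compound 2 to compound 4, 5.1 percentage points apart, within the scatter of two such steps. In this assay, both changes therefore carry across these two cores without a detectable difference, but this rests on only four compounds, and with every one of these steps within the scatter, it does not show that either change really moves the read-out.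

From the compounds shown here alone, it remains open whether an amine or a carboxylic acid in place of nitro would give a step beyond the scatter.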